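A few compounds are considered here, and "the series" means these few. Any claim that something is new, unique, unknown or untested is made for them only; others in the source may bear on it.

Compound 1 `C=C(C)C(CCC/C=C(\c1ccccc1)c1cccnc1)C(=O)O` gives 28 nM in an assay (Equus caballus) for inhibition of Thromboxane-A synthase (Homo sapiens), using microsomes; on this read-out lower numbers stand for stronger inhibition and higher numbers for weaker inhibition. Compound 2 `CC(C)(CCC/C=C(\c1ccccc1)c1cccnc1)C(=O)O` gives 21 nM in this assay. The step of a 1.3-fold lower number from compound 1 to compound 2 (0.12 log units; within the scatter) keeps the carboxylic acid on the same chain carbon and changes only the small group attached there, so compound 1 and compound 2 sit within the scatter of each other and neither can be called stronger on these two numbers alone. Compound 3 `COC(=O)CCCC/C=C(\c1ccccc1)c1cccnc1` takes a different kind of step: (methoxycarbonyl)methyl in place of 1-carboxy-1-methylethyl on a saturated chain carbon, three bonds along the chain from a double-bonded chain carbon. Among the measured compounds shown here, the one measured step bears on it only loosely, since the acid survived that step and the numbers barely moved. Nothing measured here shows what happens when the acid itself gives way to a methyl ester. The change is therefore expected to cost potency, with a step of a 7.1-fold higher number from compound 2 to compound 3 (0.85 log units; beyond the scatter) beyond the scatter. For compound 3 the estimated value in this assay is 150 nM, within a range from 30 nM to 1000 nM.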

Compound 3, half-maximal inhibitory concentration: 100 nM
Estimate against measurement, compound 3: 1.5-fold (0.18 log units) above, and the stated range covers the measured number.
By their numbers in this assay, from the lowest: compounds 2 and 1 (each within the scatter of the next); then compound 3.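

In this assay the change to the methyl ester shows a 4.8-fold higher number from compound 2 to compound 3 (0.68 log units; beyond the scatter) and also a 3.6-fold higher number from compound 1 to compound 3 (0.55 log units; beyond the scatter) in the same direction, both modest but beyond the scatter. Among the compounds shown here, this position therefore responds to this change, whereas the one step between the two acids stayed within the scatter. Even so, compound 3 gives 100 nM and so keeps measurable inhibition without a free carboxylic acid, and nothing available here explains the rise.

The change also removes the branching at the chain end, so the compounds shown cannot separate the loss of the acid from the loss of the branch. A simple carboxymethyl group would address that, and an ethyl ester or a primary amide in the same place would show whether other replacements of the acid behave like the methyl ester.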